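The compounds below may be only part of what the source reports. "The series", "measured", "known", "first", "only" and "open" are said of these compounds alone.

Compound 1, `Fc1cccc(-c2nc(Nc3ccccc3)c3cc(F)ccc3n2)c1`, in a functional assay on U-937 cells (Homo sapiens) for cytotoxicity, read by MTT assay, with a stated time of 48 h; a higher number here means a weaker inhibitor, a lower number a stronger inhibitor: 45500 nM
Compound 2, `Fc1cccc(Nc2nc(-c3cccc(F)c3)nc3ccc(F)cc23)c1`, in this assay: 42300 nM
Compound 3, `Fc1cccc(-c2nc(Nc3ccc(Cl)cc3)c3cc(F)ccc3n2)c1`, in this assay: 32700 nM

Among these three numbers compound 2 stands second highest. Its nearest neighbour is compound 1, and the step of a 1.1-fold lower number from compound 1 to compound 2 (0.03 log units; within the scatter) lies within the scatter; its furthest is compound 3, and the step of a 1.3-fold lower number from compound 2 to compound 3 (0.11 log units; within the scatter) also lies within the scatter. The three measured compounds therefore cannot be ordered in this assay on the numbers shown.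

Compound 4, `Fc1cccc(-c2nc(Nc3ccccc3Br)c3cc(F)ccc3n2)c1`, has not yet been measured. It differs from compound 2 in one place: 2-bromophenyl in place of 3-fluorophenyl on a nitrogen on an aromatic ring. For the measured compounds named here, three measured steps bear on this change. The step of a 1.3-fold lower number from compound 2 to compound 3 (0.11 log units; within the scatter) exchanges the same ring on the same nitrogen; the steps of a 1.1-fold lower number from compound 1 to compound 2 (0.03 log units; within the scatter) and a 1.4-fold lower number from compound 1 to compound 3 (0.14 log units; within the scatter) each add a halogen to that ring. None of them moves the number beyond the scatter, and compound 4 carries a halogen on the same ring in yet another arrangement. The expected step of a 1.1-fold lower number from compound 2 to compound 4 (0.05 log units; within the scatter) is thus none beyond the scatter. The estimate for compound 4 in this assay is 38000 nM, with a range from 19000 nM to 76000 nM.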

Compound 4, half-maximal inhibitory concentration: > 50000 nM
Compound 4: only a limit was reported; the forecaster's own chance of this, stated with the estimate: 5%; middle value at least 1.3-fold (0.11 log units) away from the limit.
By their numbers in this assay, from the lowest: compounds 3, 2 and 1 (each within the scatter of the next). At a limit, above all of these: compound 4.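

In this assay compound 4 is the one compound of the four reported only as a limit, not as a number: the limit of > 50000 nM in this assay, at which 1 of the 4 values shown sits.

For the compounds shown here, its steps can therefore be read only as floors: an at least 1.1-fold higher number from compound 2 to compound 4 (0.07 log units; that floor lies within the scatter), an at least 1.5-fold higher number from compound 3 to compound 4 (0.18 log units; that floor lies within the scatter) and an at least 1.0-fold higher number from compound 1 to compound 4 (0.04 log units; that floor lies within the scatter), and none of these floors establishes a real difference from the earlier compounds. What is new is that the change on the nitrogen, here to 2-bromophenyl, gives a reading with no upper end, whereas phenyl, 3-fluorophenyl and 4-chlorophenyl at the same place all gave numbers, so this position may tolerate the change with little effect or may lose much more than the floors show.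

The compounds shown leave open how far past the limit the true value of compound 4 lies, and whether its reading follows from the bromo group itself or from where that group sits on the ring. They also leave open how a ring at this place bearing an amine, a methoxy group or a carboxylic acid would read in this assay.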